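N-ethyl in place of N-methyl on a quinoxaline-free described core

The source may hold more compounds than are shown below. What is called first, only, known or untested is meant among the compounds shown, and "the series" means these compounds.

Compound 1 `COc1ccc(N(C)Cc2nc3cc(C(F)(F)F)ccc3nc2-c2ccccc2)cc1` was tested in an assay on isolated protein for inhibition of Dihydrofolate reductase (Homo sapiens), read by spectrophotometry (a higher number here means a weaker inhibitor, a lower number a stronger inhibitor), where compound 1 gives 3000 nM. Its closest neighbour among the measured compounds is compound 2 `CN(Cc1nc2cc(C(F)(F)F)ccc2nc1-c1ccccc1)c1ccc(OC(F)(F)F)cc1`, which in this assay gives 3000 nM, so that compound 1 stands level with compound 2 at the digits shown. Among the compounds with values here, the one step between them, no change at the digits printed from compound 1 to compound 2 (within the scatter), left the inhibition constant unchanged within the scatter.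

Compound 3 `CCN(Cc1nc2cc(C(F)(F)F)ccc2nc1-c1ccccc1)c1ccc(OC)cc1` differs from compound 1 in a different part of the molecule: methyl in place of hydrogen on a saturated chain carbon bound to a nitrogen on an aromatic ring. Within the data shown here, no measured step touches this saturated chain carbon; the only step available, from compound 1 to compound 2, concerned the oxygen substituent on the aromatic ring and was flat. With nothing in the data pointing to a gain or a loss, the expectation for this assay is a step of no change at the digits printed from compound 1 to compound 3 (within the scatter), that is, no change beyond the scatter. Compound 3 is therefore estimated to give 3000 nM in this assay, with a range from 1000 nM to 9000 nM.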

Compound 3, inhibition constant: 7000 nM
Compound 3: middle estimate off by 2.3-fold (0.37 log units), on the low side; the range from low to high includes it.
By their numbers in this assay, from the lowest: compounds 1 and 2 (each within the scatter of the next); then compound 3.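

The methyl to ethyl change, made on a saturated chain carbon bound to a nitrogen on an aromatic ring, gave a 2.3-fold higher number from compound 1 to compound 3 (0.37 log units; beyond the scatter) in this assay and so made compound 3 the weaker inhibitor of that pair. The earlier step, no change at the digits printed from compound 1 to compound 2 (within the scatter), changed a different place and stayed within the scatter, so this is the first place in the series shown where a change moves the inhibition constant beyond the scatter, although only modestly and in the direction of weaker inhibition. The data offer no measured basis for explaining this loss.

This single step cannot show whether the number keeps rising along a longer chain such as propyl or butyl at this position, or whether a branched group such as isopropyl, a ring such as cyclopropyl, or a hydrogen in place of the methyl on the nitrogen would read differently. It also leaves open whether the methyl to ethyl change would have the same size with the trifluoromethyl on the oxygen of compound 2, or with an amine or a carboxylic acid on the aromatic ring.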